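A few compounds are considered here, and "the series" means these few. Any claim that something is new, unique, unknown or untested is made for them only; others in the source may bear on it.

Measured in a functional assay on HUVEC cells (Homo sapiens) for inhibition, with a stated time of 4 days; a higher number here means a weaker inhibitor, a lower number a stronger inhibitor:
- compound 1 `COC(=O)c1ccc(OC)c(COc2ccc(Cl)c(C)c2)c1`: 2300 nM
- compound 2 `COc1ccc(C(N)=O)cc1/C=C\c1ccc(Cl)cc1`: 2900 nM
- compound 3 `COc1ccc(C(N)=O)cc1/C=C/c1ccccc1`: 2400 nM

These three numbers lie within the usual scatter of one another, so the data cannot separate them. Compound 3, at 2400 nM, stands level with the other two, even though the structures differ in more than one place. For the measured compounds named here, no measured pair isolates a single change, so there is no direct precedent for the next step.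

Compound 4 `COc1ccc(C(N)=O)cc1/C=C/c1ccc(C)cc1` takes compound 3 and makes one small edit: methyl in place of hydrogen on an aromatic carbon, para to a large group (methyl in place of hydrogen on an aromatic carbon). Going by the values given here, with so little to go on, the flat spread from compound 1 at 2300 nM to compound 2 at 2900 nM is the only guide, and it points to no particular direction. The expected step is none beyond the scatter, and the estimated 1.1-fold lower number from compound 3 to compound 4 (0.04 log units; within the scatter) reflects this. Compound 4 is expected to give about 2200 nM, with an estimated range of 900 nM to 5000 nM.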

Compound 4, half-maximal inhibitory concentration: 1600 nM
Compound 4: middle estimate off by 1.4-fold (0.14 log units), on the high side, and the stated range covers the measured number.
By their numbers in this assay, from the lowest: compounds 4, 1, 3 and 2 (each within the scatter of the next).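

For the compounds shown here, compound 3 and compound 4 form the first pair that differs in one place only, so a single edit can now be read on its own in this assay (methyl in place of hydrogen on an aromatic carbon, para to a large group, gives a 1.5-fold lower number from compound 3 to compound 4 (0.18 log units; within the scatter) as its step). This step does not separate the two compounds, so this one pair shows that the position accepts a methyl without a measurable change in this assay. Nothing measured here offers an explanation for this result.

From the compounds shown here alone, what remains open is whether a different group at this position, such as an amine, a carboxylic acid or a longer chain, would move the number beyond the scatter. One pair also cannot show whether the methyl would behave the same way on the core of compound 1.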